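The compounds below may be only part of what the source reports. "The series", "measured", "known", "first", "only" and "open" are said of these compounds alone.

The measured compounds:

compound 1, `COC(=O)CC1c2ccccc2N=C(N2CCCCC2)N1C(C)C`: 8%
compound 2, `COC(=O)CC1c2ccccc2N=C(N2CCOCC2)N1C(C)C`: about 0%
compound 3, `O=C(O)CC1c2ccccc2N=C(N2CCCCC2)N1c1ccccc1`: 8%

All three were tested in a functional assay on cells (Oocyte) for inhibition of Voltage-dependent T-type calcium channel subunit alpha-1H (Homo sapiens), tested at 100 uM; on this read-out lower numbers stand for less inhibition and higher numbers for more inhibition at the one concentration tested (going by the name of the read-out). Compound 1 gives 8% in this assay, and compound 3 gives 8%; the two values stand level at the digits reported, and how the two cores differ is not broken down here. Compound 2 arises from compound 1 by one change, (morpholin-4-yl in place of piperidin-1-yl on a carbon with a double bond to nitrogen). In this assay compound 2 gives about 0%. For the measured compounds named here, the step made by that change is a number 8 percentage points lower from compound 1 to compound 2 (within the scatter), so the series as a whole shows little inhibition at the single concentration tested, and no compound can be set apart from the others.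

Compound 4, `O=C(O)CC1c2ccccc2N=C(N2CCOCC2)N1c1ccccc1`, has not yet been measured. It arises from compound 3 by the same kind of change, (morpholin-4-yl in place of piperidin-1-yl on a carbon with a double bond to nitrogen). The place differs only in its surroundings: in compound 3 the carbon with a double bond to nitrogen is next to the ring atom that bears a phenyl group and two ring bonds from the ring atom that bears a carboxymethyl group, whereas in compound 1 that carbon is next to the ring atom that bears an isopropyl group and two ring bonds from the ring atom that bears a (methoxycarbonyl)methyl group.

Because the earlier step was a number 8 percentage points lower from compound 1 to compound 2 (within the scatter), the expected step for compound 4 in this assay is a number 5 percentage points lower from compound 3 to compound 4 (within the scatter), a change of the same modest size. Compound 4 is therefore expected to give 3% in this assay, with a likely range from 0% to 14%.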

Compound 4, a percentage reported as inhibition, at one concentration (the size of the read-out at that concentration, not a potency): 9%
Compound 4: the middle estimate sits 6 percentage points below what was measured; the range from low to high includes it.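

In this assay the replacement of piperidin-1-yl by morpholin-4-yl on the carbon with a double bond to nitrogen makes a step of a number 1 percentage points higher from compound 3 to compound 4 (within the scatter) on the core of compound 3. Set beside the same change on the core of compound 1, this step gives no sign that the outcome depends on the core: the same change on two cores in this assay, a number 8 percentage points lower (within the scatter) from compound 1 to compound 2 and a number 1 percentage points higher (within the scatter) from compound 3 to compound 4, 9 percentage points apart, within the scatter of two such steps. For the compounds shown here, this shows only that neither core gives a step that stands clear of the scatter, and it does not show that the change has a defined size that carries from one core to another, nor that it has no effect at all, as the evidence is one pair on each of two cores, all with little inhibition at a single concentration.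

The compounds shown leave open whether another group on that carbon, such as a piperazine or an open-chain dialkylamine, would give a reading in this assay that stands apart from these. They also leave open how the same change behaves on a core carrying a benzyl group in place of the isopropyl or phenyl group, or a primary amide in place of the ester or carboxylic acid.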